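This account rests on a few compounds, and the source may have more. Where it says the series, first, only, none or still open, it means among the compounds named here.

Compound 1, `O=C1NCCN1c1ccc(S(=O)(=O)Nc2ccc(OC(F)F)cc2)cc1`; in a functional assay on M21 cells (Homo sapiens) for antiproliferative activity, read by sulforhodamine B assay, with a stated time of 48 h (on this read-out higher numbers stand for weaker inhibition and lower numbers for stronger inhibition), compound 1 gives 410 nM.
Compound 2, `Cc1cc(C)cc(NS(=O)(=O)c2ccc(N3CCNC3=O)cc2)c1`; compound 2 gives 63 nM.
Compound 3, `Cc1cccc(NS(=O)(=O)c2ccc(N3CCNC3=O)cc2)c1`; compound 3 gives 69 nM.

Among these three numbers compound 3 lies close to compound 2, the two within the usual scatter of each other, so no order can be read between them. Compound 1 gives a clearly higher number than compound 3, and that gap lies beyond the scatter.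

Compound 4 is `O=C1NCCN1c1ccc(S(=O)(=O)Nc2ccccc2)cc1`. It differs from compound 3 by hydrogen in place of methyl on an aromatic carbon. For the measured compounds named here, the one measured step that bears on this change is a 1.1-fold higher number from compound 2 to compound 3 (0.04 log units; within the scatter), also a hydrogen in place of a methyl on an aromatic carbon of the same ring, and it stayed within the scatter. Going by the values given here, with only that single precedent, the expectation for compound 4 is that removing the remaining methyl will likewise move the number by no more than the scatter, in no definite direction. Compound 4 is therefore expected to give 80 nM, with a likely range from 40 nM to 160 nM. The step of a 1.2-fold higher number from compound 3 to compound 4 (0.06 log units; within the scatter) is expected to fall within the scatter, though a modest drift to a higher number cannot be excluded, given that compound 1, with a larger group on that ring, gives 410 nM.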

Compound 4, half-maximal inhibitory concentration: 200 nM
Estimate against measurement, compound 4: 2.5-fold (0.40 log units) below; measured number above the stated range.
By their numbers in this assay, from the lowest: compounds 2 and 3 (each within the scatter of the next); then compound 4; then compound 1.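

In this assay the change from 3-methylphenyl to phenyl is a real step (a 2.9-fold higher number from compound 3 to compound 4 (0.46 log units; beyond the scatter)), so the methyl that remains on the aromatic carbon meta to a large group matters, although the earlier loss of a methyl stayed within the scatter (a 1.1-fold higher number from compound 2 to compound 3 (0.04 log units; within the scatter)). Losing both methyls in one comparison gives a step of similar size (a 3.2-fold higher number from compound 2 to compound 4 (0.50 log units; beyond the scatter)), while hydrogen in place of difluoromethoxy moves the number the other way (a 2.1-fold lower number from compound 1 to compound 4 (0.31 log units; beyond the scatter)), so across these compounds the effect of placing hydrogen depends on the group that leaves. No measurement available here explains this difference between the groups or the contrast between the two methyl losses.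

The compounds shown leave open whether a longer chain such as ethyl, or a halogen such as chlorine, in place of the methyl would keep the number near that of compound 3 (69 nM) or move it away. They also leave open whether an amine or a methoxy group at that place would follow methyl or difluoromethoxy.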